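The source may hold more compounds than are shown below. What is called first, only, known or untested is meant among the compounds shown, and "the series" means these compounds.

Among the compounds with values here, compound 1 `CNc1nc(NCc2ccc(OC(F)(F)F)cc2)cc(-c2ccccn2)n1` gives 7 nM in a functional assay on HEK293 cells for agonist activity at G-protein coupled receptor 39 (Mus musculus), read by inositol phosphate accumulation (on this read-out higher numbers stand for an effect only at larger amounts of compound and lower numbers for an effect already at smaller amounts), and stands lowest of the two numbers so far. Compound 2 `CC(C)(C)CNc1nc(NCC2CC2)cc(-c2ccccn2)n1` gives 1500 nM in this assay, a gap from compound 1 well beyond the scatter. Compound 3 `CNc1nc(NCc2ccc(N(C)C(C)=O)cc2)cc(-c2ccccn2)n1` is not yet measured; it differs from compound 1 by acetyl(methyl)amino in place of trifluoromethoxy on an aromatic carbon. Within the data shown here, no pair of measured compounds covers this change, so no direction is fixed by the data. The step expected in this assay is a 5.7-fold higher number from compound 1 to compound 3 (0.76 log units; beyond the scatter), a moderate loss. Compound 3 is estimated at 40 nM, with a range of 8 nM to 200 nM in this assay.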

Compound 3, half-maximal effective concentration: 2610 nM
Estimate against measurement, compound 3: 65-fold (1.81 log units) below; the whole stated range lies below it.
By their numbers in this assay, from the lowest: compound 1; then compounds 2 and 3 (each within the scatter of the next).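

Acetyl(methyl)amino in place of trifluoromethoxy on the aromatic carbon gives a 370-fold higher number from compound 1 to compound 3 (2.57 log units; beyond the scatter) in this assay. Both groups count 5 heavy atoms, no ring and the same hydrogen-bond donors and acceptors, so these counts alone do not settle the outcome at this position. No measured evidence bears on the reason for this loss.

On these data alone, whether a methoxy group, trifluoromethyl or a chlorine atom at this position stays near compound 1 remains open. So does whether an unmethylated acetylamino group shows the same loss.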